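Swapping fluoro for 1-hydroxyethyl: expected acid dissociation

This account rests on a few compounds, and the source may have more. Where it says the series, first, only, none or still open, it means among the compounds named here.

Compound 1 `CC(=O)NCc1cccc(Cn2nc(NS(=O)(=O)c3ccc(Cl)s3)c3c(F)cccc32)c1` gives 5.62 in a physicochemical assay for acid dissociation.
Compound 2 `CC(=O)NCc1cccc(Cn2nc(NS(=O)(=O)c3ccc(Cl)s3)c3c(C#N)cccc32)c1` gives 5.4 in this assay.
Compound 3 `CC(=O)NCc1cccc(Cn2nc(NS(=O)(=O)c3ccc(Cl)s3)c3c(C(C)=O)cccc32)c1` gives "not determined" (no result reported) in this assay, which means no result was reported for it.

For the measured compounds named here, of the two numbers, compound 1 stands highest, with compound 2 nearest; the only step between them, a number 0.22 log units lower from compound 1 to compound 2 (within the scatter), lies within the scatter, so the two cannot be ordered. Compound 4 `CC(=O)NCc1cccc(Cn2nc(NS(=O)(=O)c3ccc(Cl)s3)c3c(C(C)O)cccc32)c1` differs from compound 1 in one place: 1-hydroxyethyl in place of fluoro on an aromatic carbon. Going by the values given here, no measured step covers this exact change; the one step at this position, a number 0.22 log units lower from compound 1 to compound 2 (within the scatter), stayed within the scatter, so no step beyond the scatter is expected in this assay. Compound 4 is therefore expected to give about 5.7, most likely between 5.3 and 6.1. This estimate means a number 0.08 log units higher from compound 1 to compound 4 (within the scatter), a step expected to remain within the scatter.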

Compound 4, acid dissociation constant: 5.62
The estimate for compound 4 lay 0.08 log units above the measured number; low and high end bracket the measured number.
By their numbers in this assay, from the lowest: compounds 2, 1 and 4 (each within the scatter of the next).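

In this assay, swapping fluoro for 1-hydroxyethyl brings no change at the digits printed from compound 1 to compound 4 (within the scatter) and swapping cyano for 1-hydroxyethyl brings a number 0.22 log units higher from compound 2 to compound 4 (within the scatter). Compound 1, compound 2 and compound 4 therefore cannot be ordered, even though 1-hydroxyethyl carries a hydrogen-bond donor that fluoro and cyano lack. No supporting measurement is available to explain this result. Still open, on these data alone, is whether an amine or a carboxylic acid on this aromatic carbon would produce a step beyond the scatter in this assay.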